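Methoxy for Dimethylamino on the Benzyl Arm

This account rests on a few compounds, and the source may have more. Where it says the series, first, only, none or still open, it means among the compounds named here.

Measured compounds:
compound 1 `CSc1cc(C)nc(SC)c1NC(=O)N(Cc1ccc(N(C)C)cc1)Cc1cccc(-c2cc[nH]n2)c1` — 72 nM
compound 2 `O=C(Nc1c(F)cc(F)cc1F)N(Cc1ccccc1)Cc1cccc(-c2cc[nH]n2)c1` — 14 nM
compound 3 `Cc1cc(C)c(NC(=O)N(Cc2ccccc2)Cc2cccc(-c3cc[nH]n3)c2)c(C)c1` — 21 nM

In an assay on small intestine for displacement of a labelled ligand from acyl-CoA:cholesterol acyltransferase (Oryctolagus cuniculus) (a lower number here means a stronger inhibitor, a higher number a weaker inhibitor), compound 1 gives the highest number of the three. Compound 3 gives 21 nM and compound 2 gives 14 nM, and both of these gaps to compound 1 lie beyond the scatter. Compound 4 `COc1ccc(CN(Cc2cccc(-c3cc[nH]n3)c2)C(=O)Nc2c(SC)cc(C)nc2SC)cc1` differs from compound 1 in one place: methoxy in place of dimethylamino on an aromatic carbon. Among the measured compounds shown here, the only measured single step, a 1.5-fold higher number from compound 2 to compound 3 (0.18 log units; within the scatter), concerns the aryl group on the urea nitrogen rather than the benzyl arm, so no measured step bears directly on this change. Without such a precedent, compound 4 is expected to stay close to compound 1, with a step of a 1.0-fold lower number from compound 1 to compound 4 (0.01 log units; within the scatter) and no shift beyond the scatter. Compound 4 is therefore estimated at 70 nM in this assay, within a range from 30 nM to 160 nM.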

Compound 4, half-maximal inhibitory concentration: 200 nM
Compound 4: the middle estimate sits 2.9-fold (0.46 log units) below what was measured; measured number above the stated range.
By their numbers in this assay, from the lowest: compounds 2 and 3 (each within the scatter of the next); then compound 1; then compound 4.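

In this assay, the group on this benzyl arm matters: with the rest of the core unchanged, 4-methoxybenzyl in place of 4-(dimethylamino)benzyl gives a 2.8-fold higher number from compound 1 to compound 4 (0.44 log units; beyond the scatter). The two groups match in hydrogen-bond donors, acceptors and net charge, so these counts do not separate them. Nothing measured here accounts for the shift.

From the compounds shown here alone, it remains open whether an amine such as morpholine or a carboxylic acid at this place would fall nearer compound 1 or compound 4. Also open, going by these compounds, is whether the same step holds with the aryl group of compound 2 on the urea.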